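Removing the acetyl from compound 1: what to expect

The compounds below may be only part of what the source reports. "The series", "measured", "known", "first", "only" and "open" are said of these compounds alone.

Measured compounds in a functional assay on HeLa cells (Homo sapiens) for cytotoxicity, read by WST assay, with a stated time of 48 h; a lower number here means a stronger inhibitor, a higher number a weaker inhibitor:
- compound 1, `COc1ccc(/C=C/C[C@@H]2C[C@@H]([C@@H](OC(C)=O)c3ccc(OC)c(OC)c3)CO[C@H]2c2ccc(OC)c(OC)c2)cc1OC`, gives > 100000 nM, which is a limit of the assay rather than a number.
- compound 2, `COc1ccc(/C=C/C[C@H]2C[C@@H]([C@@H](O)c3ccccc3)CO[C@@H]2c2ccc(OC)c(OC)c2)cc1OC`, gives 15500 nM.
- compound 3, `COc1ccc(/C=C/C[C@H]2C[C@@H]([C@@H](OC(C)=O)c3ccc(OC)c(OC)c3)CO[C@@H]2c2ccc(OC)c(OC)c2)cc1OC`, gives > 100000 nM, again a limit of the assay and not a number.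

Compound 1 therefore stands at the limit, as noted in the limit of > 100000 nM in this assay, at which 2 of the 3 values shown sit; only compound 2, carrying a free hydroxy group on a phenyl-bearing carbon and a different drawn configuration, gives a number. Among the compounds with values here, the single step between measured compounds, a step that the two limits leave unreadable from compound 1 to compound 3, cannot be read because the fact that compounds 1 and 3 differ only in the configuration as drawn and both ends sit at the limit.

Compound 4, `COc1ccc(/C=C/C[C@@H]2C[C@@H]([C@@H](O)c3ccc(OC)c(OC)c3)CO[C@H]2c2ccc(OC)c(OC)c2)cc1OC`, differs from compound 1 by hydrogen in place of acetyl on an oxygen on a saturated carbon, that is acetoxy to hydroxy. Within the data shown here, no measured step isolates this change. Among the measured compounds shown here, the only hint is that compound 2, with a hydroxy group, gives a number while the two acetates sit at the limit, but compound 2 also differs in configuration and aryl group, so that hint is weak. Compound 4 is therefore expected to gain modestly, an at least 2.5-fold lower number from compound 1 to compound 4 (0.39 log units; beyond the scatter), and its estimated value is 40000 nM, likely between 10000 nM and 150000 nM.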

Compound 4, half-maximal inhibitory concentration: 30600 nM
Compound 4: the middle estimate sits 1.3-fold (0.12 log units) above what was measured; low and high end bracket the measured number.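

In this assay, the change from acetoxy to hydroxy can now be read on its own, with the rest of the structure untouched: the change gives an at least 3.2-fold lower number from compound 1 to compound 4 (0.51 log units; beyond the scatter). The earlier hint from compound 2 came mixed with a different aryl group and a different drawn configuration, whereas here only the acetyl leaves, so removing it alone is enough to give a measurable number. The size of this step is only a lower bound, because the acetate end of the step sits at the assay's limit: the limit of > 100000 nM in this assay, at which 2 of the 4 values shown sit.

The compounds shown leave open the true size of the step and whether the same change would lower the number in the drawn configuration of compound 3. They also leave open what a methoxy group or an amine would do in place of the hydroxy group on this carbon.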